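Shifting the Methyl on the Aryl Group of a Fused Core

The compounds below may be only part of what the source reports. "The series", "measured", "known", "first", "only" and "open" are said of these compounds alone.

Compound 1, `COc1ccc(-c2nc3c(NC4CCCC4)ncnc3n2C)cc1`: 75 nM in an assay on CHO cells for displacement of a labelled ligand from adenosine receptor A1 (Homo sapiens), read by scintillation counting, with a stated time of 3 h; on this read-out higher numbers stand for weaker inhibition and lower numbers for stronger inhibition
Compound 2, `Cc1ccccc1-c1nc2c(NC3CCCC3)ncnc2n1C`: 55 nM in this assay

Compound 2 gives the lowest of the two numbers in this assay, though compound 1 lies within the scatter of it, so no order can be read between them. Compound 3, `Cc1cccc(-c2nc3c(NC4CCCC4)ncnc3n2C)c1`, differs from compound 2 by 3-methylphenyl in place of 2-methylphenyl on an aromatic carbon. Among the compounds with values here, the only step available, a 1.4-fold lower number from compound 1 to compound 2 (0.13 log units; within the scatter), exchanged one aryl group for another and stayed within the scatter. A like outcome is expected for the step of a 1.1-fold higher number from compound 2 to compound 3 (0.04 log units; within the scatter), with no clear direction. Compound 3 is therefore estimated at 60 nM, ranging from 20 nM to 180 nM.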

Compound 3, inhibition constant: 6.2 nM
Estimate against measurement, compound 3: 9.7-fold (0.99 log units) above, and the stated range ends above it.
By their numbers in this assay, from the lowest: compound 3; then compounds 2 and 1 (each within the scatter of the next).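

With the same atoms joined differently, where the methyl sits on the phenyl ring matters at this place on the shared core: in this assay, moving it gives an 8.9-fold lower number from compound 2 to compound 3 (0.95 log units; beyond the scatter). Within the data shown here, exchanging the aryl group of the first compound for 3-methylphenyl gives a 12-fold lower number from compound 1 to compound 3 (1.08 log units; beyond the scatter), whereas the earlier exchange of aryl groups stayed within the scatter. Nothing given here explains this difference.

The compounds shown leave open whether the gain is specific to methyl or would persist with chlorine, ethyl or methoxy on the same ring carbon.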